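Cyclohexyl replaces an amide side chain: expected cytotoxicity

The source may hold more compounds than are shown below. What is called first, only, known or untested is meant among the compounds shown, and "the series" means these compounds.

Values from an ADME assay on MT4 cells (Homo sapiens) for inhibition, read by MTT assay, with a stated time of 4 days (on this read-out higher numbers stand for lower toxicity in this test and lower numbers for higher toxicity in this test), follow
- Compound 1 `COC(=O)c1[nH]cc(C(=O)NCc2ccc(F)cc2)c(=O)c1O` gives 19000 nM
- Compound 2 `CN(C)C(=O)Cn1ccn2cc(C(=O)NCc3ccc(F)cc3)c(=O)c(O)c2c1=O` gives > 200000 nM (a limit)

Compound 2 stands on this scale only as a limit, given as > 200000 nM and not as an exact number. Compound 3 `O=C(NCc1ccc(F)cc1)c1cn2ccn(C3CCCCC3)c(=O)c2c(O)c1=O` has cyclohexyl in place of (dimethylcarbamoyl)methyl on an aromatic nitrogen, and the rest of compound 2 stays the same. Going by the values given here, no two measured compounds differ in just one place, so no measured step can guide this change. Among the compounds with values here, compound 1 gives the only exact number (19000 nM) and has a different core, so it is only a rough guide. The expected change in this assay (an at least 3.3-fold lower number from compound 2 to compound 3 (0.52 log units; beyond the scatter)) is a step down toward higher toxicity, beyond the usual scatter. Compound 3 is estimated at 60000 nM (expected range 15000 nM to 200000 nM).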

Compound 3, half-maximal cytotoxic concentration: > 200000 nM
Compound 3: a limit, no number; the forecaster's own chance of this, stated with the estimate: 20%; middle value at least 3.3-fold (0.52 log units) away from the limit.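

Going by these compounds alone, compound 2 and compound 3 are both reported only as limits, not exact numbers, so no step between them can be read: the limit of > 200000 nM in this assay, at which 2 of the 3 values shown sit.

The compounds shown leave open whether cyclohexyl in place of (dimethylcarbamoyl)methyl changes the half-maximal cytotoxic concentration at all, and by how much.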